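Ethoxycarbonyl for propyl on the anilino ring of compound 2

A few compounds are considered here, and "the series" means these few. Any claim that something is new, unique, unknown or untested is made for them only; others in the source may bear on it.

Measured so far in an assay on FRT-Jurkat cells for inhibition of nuclear factor NF-kappa-B complex (Homo sapiens), read by flow cytometry, with a stated time of 24 h, tested at 10 uM; on this read-out lower numbers stand for less inhibition and higher numbers for more inhibition at the one concentration tested (going by the name of the read-out):
compound 1, `O=C1CCC(N2C(=O)c3ccc(Nc4ccccn4)cc3C2=O)C(=O)N1`, gives 9%;
compound 2, `CCCc1ccc(Nc2ccc3c(c2)C(=O)N(C2CCC(=O)NC2=O)C3=O)cc1`, gives 10%;
compound 3, `Cc1ccccc1Nc1ccc2c(c1)C(=O)N(C1CCC(=O)NC1=O)C2=O`, gives 2%.

Compound 2 gives the highest number of the three, but its distance to compound 1 and to compound 3 is within the scatter, so no order among the three can be drawn. The three steps that swap the group on the amine nitrogen are all flat: a number 1 percentage points higher from compound 1 to compound 2 (within the scatter), a number 7 percentage points lower from compound 1 to compound 3 (within the scatter) and a number 8 percentage points lower from compound 2 to compound 3 (within the scatter). Varying the aryl group on that nitrogen has not moved this read-out beyond the scatter anywhere in the series.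

Compound 4, `CCOC(=O)c1ccc(Nc2ccc3c(c2)C(=O)N(C2CCC(=O)NC2=O)C3=O)cc1`, differs from compound 2 as follows: ethoxycarbonyl in place of propyl on an aromatic carbon. Among the compounds with values here, the steps that bear on it are those on the same aryl ring, above all a number 8 percentage points lower from compound 2 to compound 3 (within the scatter), which was within the scatter, as were the other two. Within the data shown here, no measured step gives grounds to expect movement beyond the scatter from this kind of change, so the estimated step of no change at the digits printed from compound 2 to compound 4 (within the scatter) is expected to stay within it. Compound 4 is thus expected to give about 10% in this assay, with a range from 0% to 22%.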

Compound 4, a percentage reported as inhibition, at one concentration (the size of the read-out at that concentration, not a potency): 5%
Beside the measured number, compound 4's estimate is 5 percentage points above it; measured number inside the range.
By their numbers in this assay, from the lowest: compounds 3, 4, 1 and 2 (each within the scatter of the next).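

In this assay, within the data shown here, the earlier steps exchange the whole aryl group on the amine nitrogen, whereas the change from propyl to ethoxycarbonyl keeps the ring and alters only the group on an aromatic carbon, para to a large group, and gives a number 5 percentage points lower from compound 2 to compound 4 (within the scatter) as its step. This position therefore takes a group with 2 hydrogen-bond acceptors and a double bond outside aromatic rings in place of one with no hydrogen-bond acceptors, and the read-out does not leave the scatter, so this ring substitution is as flat here as the aryl swaps. No measurement at hand explains the flatness of this read-out at this position.

On these data alone, whether any group at this position can move the read-out beyond the scatter remains open: a carboxylic acid, an amine or a chain longer than propyl on the same aromatic carbon would test that. With a single tested concentration, the series also leaves open how these compounds would compare in potency.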